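This account rests on a few compounds, and the source may have more. Where it says the series, first, only, none or still open, it means among the compounds named here.

Compound 1 `CCOC(=O)c1c(C)nc(-c2ccccc2)n1OC` carries a methoxy on the ring nitrogen and in a functional assay on a cell-free system (plasma, Oryctolagus cuniculus) for inhibition, with stated times of 5 min, 1 min and 6 min (a lower number here means a stronger inhibitor, a higher number a weaker inhibitor), returns only a limit, > 30000 nM, which is where the limit of > 30000 nM in this assay, at which 1 of the 3 values shown sits, sits. Compound 2 `CCOC(=O)c1c(C)nc(-c2cccc(C#N)c2)n1OCCCO` gives 11400 nM in this assay, and compound 3 `CCOC(=O)c1c(C)nc(-c2cccc(C#N)c2)n1OCc1ccccc1Cl` gives 8710 nM. These two numbers are the only ones available and lie within the scatter of each other, the step being a 1.3-fold lower number from compound 2 to compound 3 (0.12 log units; within the scatter); compound 2 thus stands at one end of a very narrow pair. Compound 4 `CCOC(=O)c1c(C)nc(-c2cccc(C#N)c2)n1OCc1ccc(C)cc1` differs from compound 2 by 4-methylphenyl in place of 2-hydroxyethyl on a saturated chain carbon bound to an oxygen on an aromatic ring. Among the compounds with values here, the only measured step of the same kind, an aryl group replacing the 2-hydroxyethyl, was a 1.3-fold lower number from compound 2 to compound 3 (0.12 log units; within the scatter), within the scatter, so no change beyond the scatter is expected here either: the step is estimated at a 1.3-fold lower number from compound 2 to compound 4 (0.13 log units; within the scatter). Compound 4 is therefore expected to give about 8500 nM, likely between 3500 nM and 22000 nM.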

Compound 4, half-maximal inhibitory concentration: 6310 nM
Compound 4: the middle estimate sits 1.3-fold (0.13 log units) above what was measured; low and high end bracket the measured number.
By their numbers in this assay, from the lowest: compounds 4, 3 and 2 (each within the scatter of the next). At a limit, above all of these: compound 1.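

At this position, on a saturated chain carbon bound to an oxygen on an aromatic ring, 4-methylphenyl in place of 2-hydroxyethyl gives a 1.8-fold lower number from compound 2 to compound 4 (0.26 log units; within the scatter). 4-methylphenyl in place of 2-chlorophenyl gives a 1.4-fold lower number from compound 3 to compound 4 (0.14 log units; within the scatter). A second aryl group thus reads the same as the first in this assay, and nothing at hand gives a cause for these steps.

Open, on these data alone, is whether an amine, a carboxylic acid or a longer chain here would give a step beyond the scatter. Compound 1 gives only a limit and differs from the others in more than one place, so it cannot be compared with them.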